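Chalcone series: nitro for cyano on the aryl ring

The compounds below may be only part of what the source reports. "The series", "measured", "known", "first", "only" and "open" are said of these compounds alone.

Compound 1 `CNC(=O)c1cc(Oc2ccc(/C=C/C(=O)c3ccc(C)cc3)cc2)ccn1` gives "not determined" (no result reported) in a functional assay on A549 cells (Homo sapiens) for cytotoxicity, read by MTT assay, with a stated time of 72 h; a higher number here means a weaker inhibitor, a lower number a stronger inhibitor. Compound 2 `CNC(=O)c1cc(Oc2ccc(C(=O)/C=C/c3ccc(C#N)cc3)cc2)ccn1` gives 26400 nM in this assay and is the only number shown, so it stands alone without any comparison. Compound 3 `CNC(=O)c1cc(Oc2ccc(C(=O)/C=C/c3ccc([N+](=O)[O-])cc3)cc2)ccn1` differs from compound 2 in one place: nitro in place of cyano on an aromatic carbon. Within the data shown here, no step between measured compounds is available to calibrate this change. The value is expected to shift little, a 1.2-fold lower number from compound 2 to compound 3 (0.08 log units; within the scatter), in neither direction beyond the scatter. Compound 3 is therefore estimated at 22000 nM in this assay, with a range from 8000 nM to 60000 nM.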

Compound 3, half-maximal inhibitory concentration: > 50000 nM
Compound 3 was reported as a limit; the forecaster's own chance of this, stated with the estimate: 20%; middle value at least 2.2-fold (0.35 log units) away from the limit.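

Among these compounds, the step from 4-cyanophenyl to 4-nitrophenyl gives the first reading at this position: an at least 1.8-fold higher number from compound 2 to compound 3 (0.27 log units; that floor lies within the scatter) in this assay. For compound 3, the value of > 50000 nM is a limit of the assay and not a number. Nitro here shows no sign of a lower number than cyano, but the size of the step stays unknown since only a floor can be read: the limit of > 50000 nM in this assay, at which 1 of the 3 values shown sits.

Still open, as far as these compounds go, is how an amine or a carboxylic acid in place of cyano would read in this assay, and whether any group here gives a lower number than cyano.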